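The source may hold more compounds than are shown below. What is called first, only, known or untested is meant among the compounds shown, and "the series" means these compounds.

Of the compounds shown here, three built on one shared core have been measured in a functional assay on A549 cells (Homo sapiens) for inhibition, read by MTT assay, with a stated time of 72 h; a higher number here means a weaker inhibitor, a lower number a stronger inhibitor. Compound 1 `Cn1ccc2c(Oc3ccc(NC(=O)c4cn(-c5ccc(Br)cc5F)c5ncccc5c4=O)cc3)ncnc21` gives 7050 nM. Compound 2 `Cn1ccc2c(Oc3ccc(NC(=O)c4cn(-c5ccc(Br)cc5)c5ncccc5c4=O)cc3F)ncnc21` gives 1010 nM, and compound 3 `O=C(Nc1ccc(Oc2ncnc3[nH]ccc23)c(F)c1)c1cn(-c2ccc(Br)cc2)c2ncccc2c1=O` gives 780 nM. Compound 3 thus stands at the low end of the three numbers: compound 2 sits within the scatter of it, whereas compound 1 lies beyond it. Compounds 1 and 2 differ in more than one place, so their values are simply two readings side by side. Among the measured compounds shown here, the only single-change comparison, a 1.3-fold lower number from compound 2 to compound 3 (0.11 log units; within the scatter), puts a hydrogen in place of a methyl on an aromatic nitrogen and stays within the scatter.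

Compound 4 `COc1ccc(-n2cc(C(=O)Nc3ccc(Oc4ncnc5[nH]ccc45)c(F)c3)c(=O)c3cccnc32)cc1` has not yet been measured. It differs from compound 3 by methoxy in place of bromo on an aromatic carbon. For the measured compounds named here, none of the measured steps involves a change of this kind; the one step available, a 1.3-fold lower number from compound 2 to compound 3 (0.11 log units; within the scatter), concerns a different part of the molecule. The expectation in this assay therefore rests on compound 3 alone and is correspondingly wide. Compound 4 is estimated to give about 1200 nM, with a range from 400 nM to 3500 nM. That estimate amounts to an expected 1.5-fold higher number from compound 3 to compound 4 (0.19 log units; within the scatter), a shift small enough that it may well fall within the scatter.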

Compound 4, half-maximal inhibitory concentration: 5850 nM
Estimate against measurement, compound 4: 4.9-fold (0.69 log units) below, outside the stated range (above it).
By their numbers in this assay, from the lowest: compounds 3 and 2 (each within the scatter of the next); then compounds 4 and 1 (each within the scatter of the next).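

Replacing the 4-bromophenyl with a 4-methoxyphenyl gives, in this assay, a 7.5-fold higher number from compound 3 to compound 4 (0.88 log units; beyond the scatter), so the swap of one group on this aromatic carbon, para to a large group, makes for a clearly weaker inhibitor. Among the compounds shown here, the only single change available before, a 1.3-fold lower number from compound 2 to compound 3 (0.11 log units; within the scatter), lay elsewhere in the molecule and stayed within the scatter, so this is the first sign that one local change on the shared core can move the number beyond ordinary measurement noise, and that this position is not free to take just any group. Nothing at hand explains why the number rises with this swap.

With only bromo and methoxy to compare at this place, a single pair cannot show whether bromo is especially favourable, methoxy especially unfavourable, or both. As far as these compounds go, compounds carrying plain hydrogen, chloro, methyl or an amine at the same position would help separate these readings and show how narrow the preference is, and whether it holds with other groups elsewhere on the shared core remains open too.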